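The source may hold more compounds than are shown below. What is called first, only, known or untested is meant among the compounds shown, and "the series" means these compounds.

Measured so far:
compound 1 `Clc1ccccc1/C=N/Nc1nc2ccccc2nc1Cc1ccccc1` — 87000 nM
compound 2 `C/C(=N\Nc1nc2ccccc2nc1Cc1ccccc1)c1ccc(O)cc1` — 8400000 nM

Working notes. Of the compounds shown here, two have been measured in an assay on isolated protein for inhibition of Amine oxidase [flavin-containing] B (Homo sapiens), read by spectrophotometry; a higher number here means a weaker inhibitor, a lower number a stronger inhibitor. Compound 1 gives 87000 nM. Compound 2 gives 8400000 nM, the higher of the two numbers; the gap between compound 1 and compound 2 is a large one, well beyond the scatter, so compound 2 is the weaker inhibitor of the pair. For the measured compounds named here, the two differ in more than one place, so no single step is drawn between them; only the two values themselves are to be read.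

Compound 3 `C/C(=N\Nc1nc2ccccc2nc1Cc1ccccc1)c1ccc(N)cc1` has not yet been measured. It differs from compound 2 in one place: amino in place of hydroxy on an aromatic carbon. The shared core and the rest of the structure stay as in compound 2. Going by the values given here, no measured pair shows this change, so there is no comparison to lean on.

Expectation: with a donor and an acceptor leaving and a donor and an acceptor entering, the step from compound 2 to compound 3 is expected to be small, a 1.7-fold lower number from compound 2 to compound 3 (0.23 log units; within the scatter), and may well fall inside the scatter. Compound 3 is therefore estimated at 5000000 nM, with a range of 1500000 nM to 20000000 nM.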

Compound 3, half-maximal inhibitory concentration: 860000 nM
For compound 3 the middle estimate is 5.8-fold (0.76 log units) above the measured one; the whole stated range lies above it.
By their numbers in this assay, from the lowest: compound 1; then compound 3; then compound 2.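

In this assay, exchanging 4-hydroxyphenyl for 4-aminophenyl gives a 9.8-fold lower number from compound 2 to compound 3 (0.99 log units; beyond the scatter) and shows that this position, on an aromatic carbon para to a large group, is sensitive to the identity of its substituent. The leaving hydroxy and the entering amino have the same counts of heavy atoms, hydrogen-bond donors and hydrogen-bond acceptors, and neither carries a net charge, so these counts do not account for a step that lies beyond the scatter. No available measurement bears on what lies behind this step.

Going by these compounds, it remains open whether the step reflects something gained with amino or something lost with hydroxy, and a comparison with methoxy, a carboxylic acid or plain hydrogen at the same position would help separate those readings. It is also unknown whether the same exchange would have a similar effect on the 2-chlorophenyl-bearing structure of compound 1, which differs from compound 2 and compound 3 in more than one place and so gives no direct comparison.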